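Fluoro to chloro at the weak end of the series

This account rests on a few compounds, and the source may have more. Where it says the series, first, only, none or still open, it means among the compounds named here.

compound 1 `CCOC(=O)c1nn(-c2ccccc2)c(-c2ccc(F)cc2)c1CNC(C)(C)C`: 65400 nM; 29900 nM (2 entries)
compound 2 `CCOC(=O)c1nn(-c2ccccc2)c(-c2ccc(Cl)cc2)c1CNC(C)(C)C`: 58500 nM; > 559000 nM (2 entries)
compound 3 `CC(C)(C)NCc1c(C(=O)O)nn(-c2ccccc2)c1-c1ccc(F)cc1`: > 680000 nM

All values come from a functional assay on HT-29 cells (Homo sapiens) for inhibition, read by sulforhodamine B assay, with a stated time of 48 h; a higher number here means a weaker inhibitor of growth, a lower number a stronger inhibitor of growth. Compound 3 reaches only a limit of the assay, > 680000 nM, and its further entries give no single number either (the limit of > 680000 nM in this assay, at which 1 of the 3 values shown sits). Going by these compounds, its true value therefore remains unknown.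

Compound 4 `CC(C)(C)NCc1c(C(=O)O)nn(-c2ccccc2)c1-c1ccc(Cl)cc1` carries chloro in place of fluoro on an aromatic carbon, para to a large group: chloro in place of fluoro on an aromatic carbon. Going by the values given here, no measured pair gives a step for this change. The entries for compound 1 are 65400 nM; 29900 nM (2 entries). The entries for compound 2 are 58500 nM; > 559000 nM (2 entries). One of these two entries is a limit of the assay and not a number, so compound 2 gives no firm reference.

With compound 3 at > 680000 nM as the only anchor, no change beyond the scatter is expected in this assay. The expected at least 1.0-fold lower number from compound 3 to compound 4 (0.01 log units; that floor lies within the scatter) is therefore close to nil. A report of a limit alone is the likely outcome. For compound 4 the estimated value is 650000 nM, with an expected range of 200000 nM to 1000000 nM.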

Compound 4, concentration for 50% growth inhibition: 353000 nM
Beside the measured number, compound 4's estimate is 1.8-fold (0.27 log units) above it; measured number inside the range.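

Chloro in place of fluoro on an aromatic carbon, para to a large group, now has a first reading in the carboxylic acid series: an at least 1.9-fold lower number from compound 3 to compound 4 (0.28 log units; that floor lies within the scatter) in this assay. Compound 4 gives a plain number, 353000 nM, so this carboxylic acid can now be placed on the scale of the assay. Going by these compounds, compound 3 remains a limit of the assay at > 680000 nM, so the step has a floor only and its true size stays unknown.

The same change among the ethyl esters cannot be read as a step, and the entries give no firm comparison: the several entries of compound 2 in this assay, 58500 nM; > 559000 nM (2 entries) Open too is whether bromo on that aromatic carbon, or a primary amide in place of the carboxylic acid, would shift the number in this assay.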